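A few compounds are considered here, and "the series" means these few. Any claim that something is new, unique, unknown or untested is made for them only; others in the source may bear on it.

Measured so far in a functional assay on K562 cells (Homo sapiens) for cytotoxicity, read by MTT assay; a higher number here means a weaker inhibitor, a lower number a stronger inhibitor:
Compound 1 `C=CCOc1cc(/C=C/C(=O)c2ccc(OC)c3c2OC(C)(C)C=C3)ccc1OC` gives > 10000 nM, which is a limit of the assay rather than a number.
Compound 2 `COc1ccc(/C=C/C(=O)c2ccc(OC)c3c2OC(C)(C)C=C3)cc1OCCCN(C)C` gives 2920 nM.

Compound 1 therefore stands at the limit (the limit of > 10000 nM in this assay, at which 1 of the 2 values shown sits), with no exact value of its own. Among the measured compounds shown here, the only measured step, an at least 3.4-fold lower number from compound 1 to compound 2 (0.53 log units; beyond the scatter), concerns a different change and so bears only loosely on compound 3 `COc1ccc(/C=C/C(=O)c2ccc(OC)c3c2OC(C)(C)C=C3)cc1OC(=O)C1CC1`, in which (cyclopropylcarbonyl in place of allyl on an oxygen on an aromatic ring). For the measured compounds named here, no measured step tests this change, so a step in either direction, or none beyond the scatter, remains possible. The expected step, an at least 1.2-fold lower number from compound 1 to compound 3 (0.09 log units; that floor lies within the scatter), is therefore kept small. Compound 3 is thus estimated at 8000 nM, within 2000 nM to 30000 nM.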

Compound 3, half-maximal inhibitory concentration: 410 nM
Compound 3: middle estimate off by 20-fold (1.29 log units), on the high side, outside the stated range (below it).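

In this assay, this oxygen on an aromatic ring turns out to accept a group that does far more than the amine chain did: cyclopropylcarbonyl in place of allyl gives an at least 24-fold lower number from compound 1 to compound 3 (1.38 log units; beyond the scatter). The same group in place of 3-(dimethylamino)propyl gives a 7.1-fold lower number from compound 2 to compound 3 (0.85 log units; beyond the scatter), so an amine is not needed here for a low number. Compound 1 has only a limit, so the first step is a floor: the limit of > 10000 nM in this assay, at which 1 of the 3 values shown sits.

The compounds shown keep the carbonyl and the three-membered ring together, so which of them carries the gain stays open. An acetyl or a cyclopropylmethyl group on this oxygen would separate the two.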